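Three Sulfonamides at the Limit and a Fourth to Come

A few compounds are considered here, and "the series" means these few. Any claim that something is new, unique, unknown or untested is made for them only; others in the source may bear on it.

Compound 1 `O=S(=O)(Nc1ccc2oc(-c3ccccc3)nc2c1)c1cccc(C(F)(F)F)c1`: in an assay on cells for inhibition of HSP60/HSP10 (Homo sapiens), with a stated time of 60 min (a higher number here means a weaker inhibitor, a lower number a stronger inhibitor), compound 1 gives > 100000 nM, a limit of the assay.
Compound 2 `Cc1cccc(S(=O)(=O)Nc2ccc3oc(-c4ccccc4)nc3c2)c1`: in this assay compound 2 gives > 100000 nM, again a limit.
Compound 3 `O=S(=O)(Nc1ccc(-c2nc3ccccc3o2)cc1)c1ccccc1F`: in this assay compound 3 gives > 100000 nM, also a limit.

All three measured compounds sit at the limit of > 100000 nM in this assay, at which 3 of the 3 values shown sit, so none of them yields a number. Compound 2 therefore stands only at a limit in this assay, and the two other values shown are limits as well. Among the compounds with values here, the single measured step, a step that the two limits leave unreadable from compound 1 to compound 2, cannot be read because both of its ends are limits.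

Compound 4 `COc1ccc(S(=O)(=O)Nc2ccc3oc(-c4ccccc4)nc3c2)cc1` differs from compound 2 by 4-methoxyphenyl in place of 3-methylphenyl on a sulfonyl sulfur. No measured step bears on a change of this kind, and the one step shown is unreadable in any case. With every value shown a limit, compound 4 is expected to remain at the limit too, and a step that the limit leaves unreadable from compound 2 to compound 4 is expected to be no step beyond the scatter. Compound 4 is estimated at 150000 nM, within 50000 nM to 500000 nM, with a high chance that only a limit is reported.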

Compound 4, half-maximal inhibitory concentration: > 100000 nM
Compound 4: only a limit was reported; the forecaster's own chance of this, stated with the estimate: 85%; the middle value lies beyond the limit too.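

Within the data shown here, compound 2 and compound 4 both stand only at a limit, so no step between them can be read: the limit of > 100000 nM in this assay, at which 4 of the 4 values shown sit.

The compounds shown leave open which structure, if any, would give a number in this assay and how a group on the sulfonyl sulfur bears on it.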